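This account rests on a few compounds, and the source may have more. Where it says the series, first, only, none or still open, it means among the compounds named here.

Measured compounds:
compound 1 `CN1C[C@H](C(=O)Nc2ccc(C(F)(F)F)cc2)[C@@H](c2ccc(/C=C/C(=O)Nc3ccccc3N)cc2)C1`: 23 mL/min/kg
compound 2 `CN1C[C@H](C(=O)Nc2ccc(F)c(Cl)c2)[C@@H](c2ccc(/C=C/C(=O)Nc3ccccc3N)cc2)C1`: 34 mL/min/kg

Going by the values given here, in an in vitro ADME assay on microsomes from liver (Mus musculus) for pharmacokinetics, read by LC-MS, with a stated time of 10 min, tested at 1 uM (a lower number here means slower removal, a higher number faster removal of the compound), compound 2 gives 34 mL/min/kg, which lies within the scatter of compound 1, the only other compound measured. Compound 3 `CN1C[C@H](C(=O)Nc2cccnc2)[C@@H](c2ccc(/C=C/C(=O)Nc3ccccc3N)cc2)C1` has not yet been measured. It keeps the rest of compound 2 and differs in one place: pyridin-3-yl in place of 3-chloro-4-fluorophenyl on an amide-type nitrogen. Among the compounds with values here, the only measured step at this place is a 1.5-fold higher number from compound 1 to compound 2 (0.17 log units; within the scatter). Within the data shown here, that step exchanged one aromatic ring of carbon only for another, so no measured step shows what a ring with a hetero atom does here, and it is only a weak guide. A step beyond the scatter is therefore not expected, and the direction remains uncertain. The estimated step is a 1.3-fold lower number from compound 2 to compound 3 (0.12 log units; within the scatter). For compound 3 the expected value in this assay is 26 mL/min/kg, with an estimated range of 12 mL/min/kg to 55 mL/min/kg.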

Compound 3, clearance: 41 mL/min/kg
For compound 3 the middle estimate is 1.6-fold (0.20 log units) below the measured one, within the range that was stated.
By their numbers in this assay, from the lowest: compounds 1, 2 and 3 (each within the scatter of the next).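

In this assay, the ring with a hetero atom on the amide-type nitrogen gives a 1.2-fold higher number from compound 2 to compound 3 (0.08 log units; within the scatter), and measured against the 4-(trifluoromethyl)phenyl ring it gives a 1.8-fold higher number from compound 1 to compound 3 (0.25 log units; within the scatter). This position has therefore now held two rings of carbon only and one pyridin-3-yl ring, and all three compounds lie within the scatter of one another, even though the change from 3-chloro-4-fluorophenyl to pyridin-3-yl brings fewer heavy atoms and a hydrogen-bond acceptor. Nothing available explains this outcome.

The compounds shown leave open whether pyridin-4-yl or pyridin-2-yl would behave like pyridin-3-yl at this nitrogen. They also leave open whether a non-aromatic group, such as a piperidine ring or a short alkyl chain, or a ring carrying a carboxylic acid, would give a step beyond the scatter.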